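This account rests on a few compounds, and the source may have more. Where it says the series, first, only, none or still open, it means among the compounds named here.

In an ADME assay on microsomes from liver (Mus musculus) for metabolic stability, read by LC-MS, with a stated time of 40 min (on this read-out lower numbers stand for slow clearance and higher numbers for fast clearance), compound 1 (`Cc1ccc(C(=O)N(CC(=O)NCc2ccccc2)Cc2ccc(C(=O)NO)cc2)c(C)c1`) gives 38 mL.min-1.g-1. For the measured compounds named here, compound 2 (`CC(C)c1ccc(C(=O)N(Cc2ccc(C(=O)NO)cc2)C(C)(C)C(=O)NC2CCCCC2)cc1`) gives 30 mL.min-1.g-1, within the scatter of compound 1, and compound 3 (`Cc1ccc(C(=O)N(CC(=O)NC2CCCCC2)Cc2ccc(C(=O)NO)cc2)c(C)c1`) gives 94 mL.min-1.g-1, the one number clearly apart. In compound 4 (`O=C(CN(Cc1ccc(C(=O)NO)cc1)C(=O)c1cccc2ccccc12)NCc1ccccc1`), naphthalen-1-yl takes the place of 2,4-dimethylphenyl on a carbonyl carbon: naphthalen-1-yl in place of 2,4-dimethylphenyl on a carbonyl carbon. Going by the values given here, the only measured step, a 2.5-fold higher number from compound 1 to compound 3 (0.39 log units; beyond the scatter), was modest and came from cyclohexyl in place of benzyl on an amide-type nitrogen, so it is a change at another place and gives only a rough idea of size. Among the compounds with values here, no measured step covers the new group, and no step beyond the scatter is expected. The expected change is a 1.2-fold higher number from compound 1 to compound 4 (0.07 log units; within the scatter). Compound 4 is estimated at 45 mL.min-1.g-1, with an expected range of 20 mL.min-1.g-1 to 100 mL.min-1.g-1.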

Compound 4, intrinsic clearance in microsomes: 87 mL.min-1.g-1
Compound 4: the middle estimate sits 1.9-fold (0.29 log units) below what was measured; the measured number falls inside the stated range.
By their numbers in this assay, from the lowest: compounds 2 and 1 (each within the scatter of the next); then compounds 4 and 3 (each within the scatter of the next).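

The group on this carbonyl carbon does affect clearance in this assay, since naphthalen-1-yl in place of 2,4-dimethylphenyl gives a 2.3-fold higher number from compound 1 to compound 4 (0.36 log units; beyond the scatter). Together with a 2.5-fold higher number from compound 1 to compound 3 (0.39 log units; beyond the scatter), this means that changes at two separate places on the core of compound 1 have each moved the number beyond the scatter. Nothing available here explains the rise.

The compounds shown leave open whether the second aromatic ring or the loss of the two methyl groups matters more. A plain phenyl or a 4-methoxyphenyl group at this carbonyl carbon would help to separate the two.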